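This account rests on a few compounds, and the source may have more. Where it says the series, first, only, none or still open, it means among the compounds named here.

In an ADME assay on Vero 76 cells (Chlorocebus sabaeus) for cytotoxicity, read by MTT assay, with a stated time of 96 h (on this read-out higher numbers stand for lower toxicity in this test and lower numbers for higher toxicity in this test), compound 2 `NS(=O)(=O)c1ccc(N2N=C(c3ccc(Oc4ccccc4)cc3)CC2c2cccc(Cl)c2)cc1` gives 88000 nM and compound 1 `NS(=O)(=O)c1ccc(N2N=C(c3ccc(Oc4ccccc4)cc3)CC2c2ccccc2)cc1` gives 85000 nM, so the two stand level within the usual scatter. Compound 3 `Cc1ccccc1C1CC(c2ccc(Oc3ccccc3)cc2)=NN1c1ccc(S(N)(=O)=O)cc1` carries 2-methylphenyl in place of 3-chlorophenyl on a saturated ring carbon. For the measured compounds named here, only one measured step bears on this change: chloro in place of hydrogen on an aromatic carbon gave a 1.0-fold higher number from compound 1 to compound 2 (0.02 log units; within the scatter). Going by the values given here, no measured step swaps one whole aromatic group for another, so no shift beyond the scatter is expected in this assay, in either direction. The estimated step is a 1.1-fold lower number from compound 2 to compound 3 (0.04 log units; within the scatter). For compound 3 the expected value is 80000 nM, within an estimated range of 40000 nM to 100000 nM.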

Compound 3, half-maximal cytotoxic concentration: 90000 nM
Beside the measured number, compound 3's estimate is 1.1-fold (0.05 log units) below it; measured number inside the range.
By their numbers in this assay, from the lowest: compounds 1, 2 and 3 (each within the scatter of the next).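

In this assay, replacing the whole aromatic group on this saturated ring carbon gives a 1.0-fold higher number from compound 2 to compound 3 (0.01 log units; within the scatter), and a methyl in place of hydrogen on the aromatic ring gives a 1.1-fold higher number from compound 1 to compound 3 (0.02 log units; within the scatter). The position has therefore taken phenyl, 3-chlorophenyl and 2-methylphenyl with every step within the scatter, and this is the first whole-group swap shown. No evidence is available on why the numbers stay level. From the compounds shown here alone, whether an amine or a carboxylic acid on this aromatic ring would also leave the number level remains open, as does replacing the ring with cyclohexyl.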